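A few compounds are considered here, and "the series" means these few. Any claim that something is new, unique, unknown or untested is made for them only; others in the source may bear on it.

Compound 2 `CNCc1ccc(Cl)c(-c2ccccc2OC)c1` gives 1200 nM in an assay on isolated protein for binding affinity to 5-hydroxytryptamine receptor 1B (Homo sapiens) (on this read-out lower numbers stand for stronger inhibition and higher numbers for weaker inhibition), the higher of the two numbers measured; compound 1 `COc1ccccc1-c1cc(C2CCN(C)C2)ccc1Cl` gives 12 nM, and the step of a 100-fold higher number from compound 1 to compound 2 (2.00 log units; beyond the scatter) shows how strongly the amine-bearing group governs this assay. Compound 3 `CCN(CC)Cc1ccc(Cl)c(-c2ccccc2OC)c1` carries diethylamino in place of methylamino on a saturated chain carbon bound to an aromatic carbon. Within the data shown here, no measured step changes only the substituents on the amine, so compound 3 is expected to lie close to compound 2, with a 1.2-fold lower number from compound 2 to compound 3 (0.08 log units; within the scatter) as the estimated step. Compound 3 is therefore expected to give about 1000 nM, within a range of 250 nM to 4000 nM.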

Compound 3, inhibition constant: > 10000 nM
Compound 3: no number, only a limit; the forecaster's own chance of this, stated with the estimate: 5%; middle value at least 10-fold (1.00 log units) from the limit.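

In this assay compound 3 gives > 10000 nM, which is a limit of the assay and not a number. Earlier, only the whole amine-bearing group had changed; here only the groups on the nitrogen change, and that alone gives an at least 8.3-fold higher number from compound 2 to compound 3 (0.92 log units; beyond the scatter). Measured against 1-methylpyrrolidin-3-yl, (diethylamino)methyl gives an at least 830-fold higher number from compound 1 to compound 3 (2.92 log units; beyond the scatter).

Diethylamino differs from methylamino both in size and in having no hydrogen-bond donor, and these compounds cannot separate the two. Ethylamino and dimethylamino, on a saturated chain carbon bound to an aromatic carbon, remain open.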